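Rearranging the Lactone Tail on a Shared Core

The compounds below may be only part of what the source reports. "The series", "measured", "known", "first", "only" and "open" are said of these compounds alone.

Of the compounds shown here, three built on one shared core have been measured in a functional assay on RAW264.7 cells (Mus musculus) for inhibition, with a stated time of 24 h; a lower number here means a stronger inhibitor, a higher number a weaker inhibitor. Compound 1 `C=C1CC[C@H]2C(C)(C)CCC[C@]2(C)[C@H]1C/C=C1\CC(=O)OC1=O` gives 11000 nM in this assay. Compound 2 `C=C1CC[C@H]2C(C)(C)CCC[C@]2(C)[C@H]1C/C=C(\CC(=O)OCC)C(=O)O` is reported in this assay only as a limit, > 50000 nM. Compound 3 `C=C1CC[C@H]2C(C)(C)CCC[C@]2(C)[C@H]1CCC1=CC(=O)OC1` gives 18800 nM in this assay, the higher of the two numbers; its nearest neighbour is compound 1, and the gap between the two lies within the usual scatter, so no ranking of them is drawn.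

Compound 4 `C=C1CC[C@H]2C(C)(C)CCC[C@]2(C)[C@H]1C/C=C1\CCOC1=O` carries the same atoms as compound 3, joined differently: a group of 7 heavy atoms (5 carbon, 2 oxygen; one five-membered non-aromatic ring with 1 hetero atom) in place of a group of 7 heavy atoms (5 carbon, 2 oxygen; one five-membered non-aromatic ring with 1 hetero atom), on a saturated chain carbon bound to a saturated ring carbon. The change sits on a saturated chain carbon bound to a saturated ring carbon. For the measured compounds named here, no pair of measured compounds differs in a single place, so no measured step guides the size of this one. The expected step from compound 3 to compound 4 in this assay is a 1.9-fold lower number from compound 3 to compound 4 (0.27 log units; within the scatter), a modest move toward a lower number, close to the edge of the scatter. Compound 4 is therefore expected to give about 10000 nM in this assay, with a plausible range from 3000 nM to 40000 nM.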

Compound 4, half-maximal inhibitory concentration: 30800 nM
Estimate against measurement, compound 4: 3.1-fold (0.49 log units) below; measured number inside the range.
By their numbers in this assay, from the lowest: compounds 1, 3 and 4 (each within the scatter of the next, the first and the last beyond it). At a limit, above all of these: compound 2.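

With the arrival of compound 4, the study has its first pair of measured compounds that differ in one place, and in this assay the step is a 1.6-fold higher number from compound 3 to compound 4 (0.21 log units; within the scatter). At this place, on a saturated chain carbon bound to a saturated ring carbon, two groups with the same atoms joined differently therefore cannot be told apart, so this rearrangement of the lactone tail gives no measurable separation here. No measurement shown bears on why the two groups read alike.

What the compounds shown leave open is whether a group with other atoms at this place, such as a lactam or an amine, or a longer chain carrying the ring, would give a step beyond the scatter. Going by these compounds, it also remains open whether this one step would hold on any core other than the shared one.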